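Bromination of a pyrimidine core measured for lipophilicity

This account rests on a few compounds, and the source may have more. Where it says the series, first, only, none or still open, it means among the compounds named here.

Compound 1 `Cc1cc(C#N)cc(C)c1Oc1ccnc(Nc2ccc(C#N)cc2)n1` — 1.64
Compound 2 `Cc1cc(C#N)cc(C)c1Nc1ccnc(Nc2ccc(C#N)cc2)n1` — 1.47
Compound 3 `Cc1cc(C#N)cc(C)c1Nc1nc(Nc2ccc(C#N)cc2)ncc1Br` — 1.64

Of the compounds shown here, three have been measured in a physicochemical assay for lipophilicity; on this read-out lower numbers stand for lower lipophilicity and higher numbers for higher lipophilicity. Compound 2 and compound 3 differ by one change, (bromo in place of hydrogen on an aromatic carbon), and that change gave a number 0.17 log units higher from compound 2 to compound 3 (within the scatter). Among the compounds with values here, compound 1 and compound 3 stand level in this assay at the digits printed, and the value of compound 1 and the value of compound 2 simply sit within the scatter of each other; no step between compound 1 and compound 2 is given. How the core of compound 1 differs from the core of compound 2 is not broken down here.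

Compound 4 `Cc1cc(C#N)cc(C)c1Oc1nc(Nc2ccc(C#N)cc2)ncc1Br` has not yet been measured. Within the data shown here, it differs from compound 1 by bromo in place of hydrogen on an aromatic carbon, which is the same change as the one from compound 2 to compound 3, at the same place. Because the earlier step was a number 0.17 log units higher from compound 2 to compound 3 (within the scatter), an expected step of a number 0.17 log units higher from compound 1 to compound 4 (within the scatter) is taken for compound 4. Compound 4 is therefore estimated at 1.81, with a range from 1.55 to 2.1, pending the measurement.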

Compound 4, partition coefficient: 1.82
Compound 4: the middle estimate sits 0.01 log units below what was measured, and the stated range covers the measured number.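

In this assay bromo in place of hydrogen on an aromatic carbon gave a number 0.18 log units higher from compound 1 to compound 4 (within the scatter) on the core of compound 1 and a number 0.17 log units higher from compound 2 to compound 3 (within the scatter) on the core of compound 2, so across these two pairs the step carried from one core to the other at much the same size. Both steps lie within the scatter, however, so neither pair shows that the bromo truly shifts the read-out, and two pairs set no rule for any further core. Nothing available bears on what lies behind these numbers.

The compounds shown leave open whether chloro, an amine or a carboxylic acid on that same aromatic carbon would give steps that carry between the two cores in the same way. They also leave open whether bromo would do so on a core carrying a longer chain in place of the (4-cyanophenyl)amino group.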